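Trimming the Benzyl Group in an Aminopyridine Series

The source may hold more compounds than are shown below. What is called first, only, known or untested is meant among the compounds shown, and "the series" means these compounds.

Compound 1 `CC(C)C[C@H](N)COc1ccc(-c2ccnc(NCc3ccccc3)c2)cc1` is tested in an assay on isolated protein for inhibition of AP2-associated protein kinase 1 (Homo sapiens), with a stated time of 3 h, in the presence of a further agent that is not named here (a higher number here means a weaker inhibitor, a lower number a stronger inhibitor), where compound 1 gives 127 nM. Going by the values given here, that is the higher of the two numbers known so far: compound 2 `CC(=O)Nc1cc(-c2cc(F)c(OC[C@@H](N)CC(C)C)cc2F)ccn1` gives 1.3 nM in this assay, a difference far outside the scatter. Compound 3 `CC(C)C[C@H](N)COc1ccc(-c2ccnc(N)c2)cc1` is the untested analogue; the change is hydrogen in place of benzyl on a nitrogen on an aromatic ring. Losing the whole benzyl group is expected to weaken binding modestly, a step from compound 1 to compound 3 of a 3.1-fold higher number from compound 1 to compound 3 (0.50 log units; beyond the scatter). Compound 3 is therefore estimated at 400 nM, within 100 nM to 2000 nM.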

Compound 3, half-maximal inhibitory concentration: 21 nM
For compound 3 the middle estimate is 19-fold (1.28 log units) above the measured one; measured number below the stated range.
By their numbers in this assay, from the lowest: compound 2; then compound 3; then compound 1.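

Replacing benzylamino with amino gives a 6.0-fold lower number from compound 1 to compound 3 (0.78 log units; beyond the scatter) in this assay. The benzyl group on this nitrogen is therefore not needed for inhibition here, and the bare amino compound is the stronger inhibitor of the two. Nothing measured here explains this gain.

Going by these compounds, it remains open whether a methyl or a longer phenethyl group on this nitrogen would read closer to compound 3 or to compound 1. Compound 2 differs from compound 3 in more than one place, so that pair cannot show what any single change contributes.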